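Turning One Ring Stereocentre in a Sigma-1 Ligand

The source may report more compounds than this note shows. Statements on the series, on what has been measured and on what is new or still open speak of the compounds shown alone.

Compound 1 `NCC1COCC(c2ccccc2)(c2ccccc2)O1` gives, in an assay on membranes from brain for displacement of a labelled ligand from Sigma non-opioid intracellular receptor 1 (Cavia porcellus), read by scintillation counting, with a stated time of 120 min, in the presence of a further agent that is not named here (a higher number here means a weaker inhibitor, a lower number a stronger inhibitor), only a limit of > 10000 nM. Within the data shown here, compound 2 `c1ccc(CNC[C@H]2COC[C@H](c3ccccc3)O2)cc1` gives 542 nM in this assay, the only plain number in this set. The other result shown sits at the limit of > 10000 nM in this assay, at which 1 of the 2 values shown sits. Compound 3 `c1ccc(CNC[C@@H]2COC[C@H](c3ccccc3)O2)cc1` has not been measured. It differs from compound 2 thus: the two compounds have the same atoms and bonds and differ only in configuration as drawn: 1 of 2 stereo elements differ; a stereocentre at a saturated ring carbon is drawn S in compound 2 and R in compound 3. Among the measured compounds shown here, no measured pair differing in one place is available, so the flip at one saturated ring carbon is expected to move the inhibition constant little beyond the usual scatter, if anything toward weaker binding, a step of a 1.7-fold higher number from compound 2 to compound 3 (0.22 log units; within the scatter). Compound 3 is estimated at 900 nM, within 150 nM to 5000 nM.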

Compound 3, inhibition constant: 155 nM
The estimate for compound 3 lay 5.8-fold (0.76 log units) above the measured number; the measured number falls inside the stated range.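

In this assay, turning the saturated ring carbon from S to R gives a 3.5-fold lower number from compound 2 to compound 3 (0.54 log units; beyond the scatter), so binding responds to the configuration at this position. The earlier compounds shown here offered no such comparison. The step can be assigned to this one stereocentre alone: the fact that compounds 2 and 3 differ only in the configuration as drawn

As far as these compounds go, the second stereocentre is drawn the same in compound 2 and compound 3, so the effect of turning it remains open. Also open, from the compounds shown here alone, is whether the R configuration keeps its advantage with a phenethyl group in place of the benzyl group.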